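Fluoro for Methyl on Two Related Cores

This account rests on a few compounds, and the source may have more. Where it says the series, first, only, none or still open, it means among the compounds named here.

Compound 1 `Cc1cc2c(cc1C(=O)c1ccc3cc(C(=O)O)ccc3c1)C(C)(C)CCC2(C)C` and compound 2 `CC1(C)CCC(C)(C)c2cc(C(=O)c3ccc4cc(C(=O)O)ccc4c3)c(F)cc21` share one core. In an assay on isolated protein with retinoic acid receptor alpha (Homo sapiens) as the target (on this read-out lower numbers stand for smaller maximal responses and higher numbers for larger maximal responses), compound 1 gives 26%, and compound 2 gives 34%. The change between them is fluoro in place of methyl on an aromatic carbon, and the step it made is a number 8 percentage points higher from compound 1 to compound 2 (within the scatter). Compound 3 `Cc1cc2c(cc1C(O)c1ccc3cc(C(=O)O)ccc3c1)C(C)(C)CCC2(C)C` rests on a second core; the difference between the two cores is not broken down here. In this assay compound 3 gives 0%, the lowest of the three numbers, and its gaps to compound 1 and to compound 2 both lie beyond the scatter. Compound 4 `CC1(C)CCC(C)(C)c2cc(C(O)c3ccc4cc(C(=O)O)ccc4c3)c(F)cc21` has not yet been measured in this assay; it arises from compound 3 by fluoro in place of methyl on an aromatic carbon, the same change that led from compound 1 to compound 2, with the place described word for word alike in both cases. Because the earlier step was only a number 8 percentage points higher from compound 1 to compound 2 (within the scatter), a step of similar small size is expected here too, namely a number 6 percentage points higher from compound 3 to compound 4 (within the scatter). Compound 4 is therefore expected to give about 6%, most likely between 0% and 20%, a value still close to that of compound 3.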

Compound 4, largest response reached (reported as maximum), in percent of the reference or control that the assay uses: 0%
The estimate for compound 4 lay 6 percentage points above the measured number, and the stated range covers the measured number.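

In this assay, fluoro in place of methyl on an aromatic carbon gave no change at the digits printed from compound 3 to compound 4 (within the scatter) on the second core, and the step did not differ measurably from the one on the first core: the same change on two cores in this assay, a number 8 percentage points higher (within the scatter) from compound 1 to compound 2 and no change at the digits printed (within the scatter) from compound 3 to compound 4, 8 percentage points apart, within the scatter of two such steps. On both cores shown, then, this change moved the maximal response by no more than the scatter, so the result carried over from one core to the other. Among the compounds shown here, this does not show that the change is neutral on every core, since only two pairs bear on it, and compound 3 at 0% and compound 4 at 0% offer no measurable response from which a shift could be read.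

The compounds shown leave open whether other groups at the same aromatic carbon, such as chloro, trifluoromethyl or methoxy, would behave as fluoro does here. They also leave open how the change would read on a core in which the carboxylic acid gives way to an amide or an ester.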